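This account rests on a few compounds, and the source may have more. Where it says the series, first, only, none or still open, it means among the compounds named here.

In an ADME assay on TZM cells (Homo sapiens) for cytotoxicity, with a stated time of 1 days (on this read-out higher numbers stand for lower toxicity in this test and lower numbers for higher toxicity in this test), compound 1 (`Cc1cc(CCC#N)cc(C)c1Oc1cc(Nc2ccc(C#N)cc2)c(N)cc1C(=O)N(C)C`) gives 38200 nM, and compound 2 (`Cc1cc(CCC#N)cc(C)c1Oc1cc(Nc2ccc(C#N)cc2)c(N)cc1C(=O)NC(C)C`) gives 184000 nM. These two compounds share their core with compound 3 (`Cc1cc(CCC#N)cc(C)c1Oc1cc(Nc2ccc(C#N)cc2)c(N)cc1CN1CCN(C)CC1`), but compound 3 has no number to build on: its entry reads "not determined" (no result reported). Its place on this scale is therefore unknown.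

The next compound, compound 4 (`COCc1cc(N)c(Nc2ccc(C#N)cc2)cc1Oc1c(C)cc(CCC#N)cc1C`), changes compound 3 as follows: methoxy in place of 4-methylpiperazin-1-yl on a saturated chain carbon bound to an aromatic carbon. In words, methoxy stands in place of 4-methylpiperazin-1-yl on a saturated chain carbon bound to an aromatic carbon.

Among the measured compounds shown here, only one measured step exists in this small set: a 4.8-fold higher number from compound 1 to compound 2 (0.68 log units; beyond the scatter). That step is modest but beyond the scatter. It swaps dimethylamino for isopropylamino on a carbonyl carbon, which is a different kind of change from the one made here, so it bears on compound 4 only loosely. It does show how far two close relatives of compound 4 can lie apart on this read-out.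

With no number for compound 3, no size or direction can be expected for the step to compound 4. The best guide is the span set by compound 1 and compound 2. The estimate for compound 4 is an expected 70000 nM, with an expected range from 20000 nM to 220000 nM.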

Compound 4, half-maximal cytotoxic concentration: > 200000 nM
Compound 4: only a limit was reported; the forecaster's own chance of this, stated with the estimate: 20%; at least 2.8-fold (0.45 log units) between middle value and limit.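

In this assay, compound 4 carries a limit of the assay rather than an exact number: the limit of > 200000 nM in this assay, at which 1 of the 4 values shown sits. Replacing the dimethylcarbamoyl group on the aromatic carbon with methoxymethyl gives an at least 5.2-fold higher number from compound 1 to compound 4 (0.71 log units; beyond the scatter), so this swap moves the read-out beyond the scatter, towards lower toxicity in this test, and shows that an amide at this position is not needed for such a high reading. The comparison with the isopropylcarbamoyl group gives only an at least 1.0-fold higher number from compound 2 to compound 4 (0.03 log units; that floor lies within the scatter), and that floor leaves the order of these two compounds open, while the step from compound 3 cannot be read, as compound 3 has no number.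

The compounds shown leave open how the read-out would respond to a carboxylic acid or a hydroxymethyl group at this position, or to a longer ether chain such as ethoxymethyl. They also do not tell how the (4-methylpiperazin-1-yl)methyl group of compound 3 stands against methoxymethyl, or whether a smaller amine such as dimethylaminomethyl would read closer to the amides or to compound 4.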